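The source may hold more compounds than are shown below. What is called first, only, known or untested is meant among the compounds shown, and "the series" means these compounds.

In an in vitro ADME assay on microsomes from liver (Homo sapiens) for metabolic stability (on this read-out higher numbers stand for fast clearance and lower numbers for slow clearance), compound 1 `Cc1cccc(Cn2c(=O)[nH]c3c(N)nc(C(F)(F)F)cc32)n1` gives < 8 mL.min-1.g-1, which is a limit of the assay and not a number. Compound 2 `Cc1nc(Cn2c(=O)[nH]c3c(N)nc(C(F)(F)F)cc32)cs1` gives < 7 mL.min-1.g-1, which is also only a limit. For the measured compounds named here, these two compounds provide the only measured step, a step that the two limits leave unreadable from compound 1 to compound 2, so there is no size to carry forward.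

Compound 3 `COc1ccc(Cn2c(=O)[nH]c3c(N)nc(C(F)(F)F)cc32)cn1` keeps the shared core and changes one group: 6-methoxypyridin-3-yl in place of 6-methylpyridin-2-yl on a saturated chain carbon bound to an aromatic nitrogen, (6-methoxypyridin-3-yl in place of 6-methylpyridin-2-yl on a saturated chain carbon bound to an aromatic nitrogen). With no readable step as a guide, no step beyond the scatter is expected in this assay, and neither direction can be favoured. The estimated step is a step that the limit leaves unreadable from compound 1 to compound 3. Compound 3 is expected to give about 7 mL.min-1.g-1, with an estimated range from 3 mL.min-1.g-1 to 16 mL.min-1.g-1.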

Compound 3, intrinsic clearance in microsomes: < 8 mL.min-1.g-1
Compound 3 ended at the assay's limit; the forecaster's own chance of this, stated with the estimate: 55%; the middle value is on the limit's open side.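

For the compounds shown here, compound 1, compound 2 and compound 3 all end at limits of the assay and not at numbers, so no step among them can be read in this assay. From the compounds shown here alone, how fast each is truly cleared, and whether changing the group on the shared core alters that clearance, stays open.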